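The compounds below may be only part of what the source reports. "The series", "measured", "known", "first", "only" and "open" are said of these compounds alone.

Compound 1 `COc1cc(O)c(C(=O)O)c(CCc2ccc3ccccc3c2)c1` has been assessed in an ADME assay on HepG2 cells (Homo sapiens) for cytotoxicity, read by resazurin assay, with a stated time of 24 h (on this read-out higher numbers stand for lower toxicity in this test and lower numbers for higher toxicity in this test), where compound 1 gives 71000 nM. Two further members of the series carry numbers in this assay: compound 2 `CCN(CC)C(=O)c1c(O)cc(O)cc1CCc1ccc2ccccc2c1` gives 36400 nM and compound 3 `COc1cc(O)c(C(=O)O)c(C=Cc2ccc3ccccc3c2)c1` gives 79000 nM. Compound 1 stands second highest of these three numbers; its nearest neighbour is compound 3 and its furthest is compound 2, and both gaps lie within the usual scatter, so no ordering of the three is claimed.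

Compound 4 `O=C(O)c1c(O)cc(Cl)cc1CCc1ccc2ccccc2c1` is not yet measured. It differs from compound 1 in one place: chloro in place of methoxy on an aromatic carbon. No measured pair in the series shows a change of this kind, so there is no shown step to lean on; the three measured numbers sit close together, which is the only guide. In this assay the estimated step is a 1.2-fold lower number from compound 1 to compound 4 (0.07 log units; within the scatter), expected to be small, with no direction beyond the scatter. Compound 4 is estimated at 60000 nM in this assay, with an expected range from 30000 nM to 120000 nM.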

Compound 4, half-maximal cytotoxic concentration: 35000 nM
The estimate for compound 4 lay 1.7-fold (0.23 log units) above the measured number; low and high end bracket the measured number.
By their numbers in this assay, from the lowest: compounds 4, 2, 1 and 3 (each within the scatter of the next, the first and the last beyond it).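

In this assay, among these compounds, the aromatic carbon para to the carboxy group gives the first readable step: chloro in place of methoxy gives a 2.0-fold lower number from compound 1 to compound 4 (0.31 log units; beyond the scatter), a modest change. Among the compounds shown here, the earlier compounds offered no one-place comparison, so this pair is the first to show that a substitution at this position can move the number beyond the scatter, here towards higher toxicity in this test. No measurement available here accounts for the step.

A single pair cannot separate the loss of methoxy from the arrival of chloro, so a methyl group or an amine at this position would be needed to show whether other replacements give a similar step. As far as these compounds go, whether chloro in place of methoxy gives a step of this size on compound 3 also remains open.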